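A Bicyclic Group Replaces a Branched Chain

The source may report more compounds than this note shows. Statements on the series, on what has been measured and on what is new or still open speak of the compounds shown alone.

compound 1, `CCCc1nc(C(F)(F)F)ccc1CNC(=O)C(C)c1ccc(NS(C)(=O)=O)c(F)c1`: 22.7 nM
compound 2, `CC(C(=O)NCc1ccc(C(F)(F)F)nc1CCC(C)(C)C)c1ccc(NS(C)(=O)=O)c(F)c1`: 0.6 nM
compound 3, `C[C@H](C(=O)NCc1ccc(C(F)(F)F)nc1C1CCC(C)(C)CC1)c1ccc(NS(C)(=O)=O)c(F)c1`: 0.3 nM

In an assay on CHO cells for antagonist activity at transient receptor potential cation channel subfamily V member 1 (Homo sapiens), read by FLIPR and calcium flux (on this read-out higher numbers stand for weaker inhibition and lower numbers for stronger inhibition), compound 2 gives the second highest of the three numbers; its nearest neighbour is compound 3, a gap within the scatter, while compound 1 lies far above it. Compound 4, `CC(C(=O)NCc1ccc(C(F)(F)F)nc1C1CC2CCC1C2)c1ccc(NS(C)(=O)=O)c(F)c1`, is not yet measured. It differs from compound 2 by a group of 7 heavy atoms (7 carbon; 2 five-membered non-aromatic rings of carbon only) in place of a group of 6 heavy atoms (6 carbon; no ring), on an aromatic carbon. Going by the values given here, the one measured step that bears on this place is a 38-fold lower number from compound 1 to compound 2 (1.58 log units; beyond the scatter), where a saturated group with more carbons went with a much lower number. Compound 3 also carries a saturated ring in place of the chain and gives 0.3 nM, close to compound 2. The group entering in compound 4 is again saturated and of comparable carbon count, so a number near that of compound 2 is expected, and the step from compound 2 to compound 4 is estimated as a 1.2-fold lower number from compound 2 to compound 4 (0.08 log units; within the scatter), within the scatter. Compound 4 is therefore estimated at 0.5 nM, between 0.15 nM and 1.8 nM.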

Compound 4, inhibition constant: 1.5 nM
Beside the measured number, compound 4's estimate is 3.0-fold (0.48 log units) below it, within the range that was stated.
By their numbers in this assay, from the lowest: compounds 3 and 2 (each within the scatter of the next); then compound 4; then compound 1.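

In this assay, replacing the 3,3-dimethylbutyl group with the group of two five-membered carbon rings gives a 2.5-fold higher number from compound 2 to compound 4 (0.40 log units; beyond the scatter), so a saturated carbon group of comparable size does not by itself preserve the number of compound 2 at this position on the aromatic ring. The same group still gives a 15-fold lower number from compound 1 to compound 4 (1.18 log units; beyond the scatter), so compound 4 keeps much of the large drop that compound 2 shows against compound 1. No measurement shown here accounts for the gap between the two larger groups.

The compounds shown leave open how an amine such as piperidine, or a saturated ring containing oxygen, would behave at this position, and whether a longer chain would lower the number further. As far as these compounds go, compound 4 is also drawn without a defined three-dimensional arrangement, so the numbers of its separate mirror-image forms remain open.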